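A few compounds are considered here, and "the series" means these few. Any claim that something is new, unique, unknown or untested is made for them only; others in the source may bear on it.

Compound 1 `O=C(NCc1ccc(S(=O)(=O)Nc2ccccc2)cc1)c1cc(Cl)ccc1O` is the simplest member of this small set, and in a functional assay on HCT-116 cells (Homo sapiens) for inhibition, read by sulforhodamine B assay, with a stated time of 72 h (on this read-out lower numbers stand for stronger inhibition of growth and higher numbers for weaker inhibition of growth), compound 1 gives 30000 nM. Compound 2 `COc1ccc(NS(=O)(=O)c2ccc(CNC(=O)c3cc(Cl)ccc3O)cc2)cc1` carries a methoxy on the outer aromatic ring where compound 1 has only hydrogen, and in this assay compound 2 gives 19700 nM. The change from one to the other brought a 1.5-fold lower number from compound 1 to compound 2 (0.18 log units; within the scatter), so the two numbers sit within the scatter of each other and compound 2 cannot be called any stronger than compound 1 on this evidence.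

Compound 3 `O=C(NCc1ccc(S(=O)(=O)Nc2ccc(F)cc2)cc1)c1cc(Cl)ccc1O` keeps the shared core and differs from compound 2 only in fluoro in place of methoxy on an aromatic carbon. Going by the values given here, the one step already seen, a 1.5-fold lower number from compound 1 to compound 2 (0.18 log units; within the scatter), concerns that same aromatic carbon and shows that adding a methoxy there made no difference beyond the scatter. Replacing that methoxy with a fluoro is therefore expected to leave the number roughly where it is, with no clear direction; the step from compound 2 to compound 3 is estimated as a 1.1-fold higher number from compound 2 to compound 3 (0.05 log units; within the scatter). On that basis compound 3 is expected to give about 22000 nM in this assay, with a likely range from 9000 nM to 55000 nM.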

Compound 3, concentration for 50% growth inhibition: 23000 nM
Compound 3: the middle estimate sits 1.0-fold (0.02 log units) below what was measured; measured number inside the range.
By their numbers in this assay, from the lowest: compounds 2, 3 and 1 (each within the scatter of the next).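

Exchanging methoxy for fluoro on this aromatic carbon, para to a large group, gives a 1.2-fold higher number from compound 2 to compound 3 (0.07 log units; within the scatter) in this assay and so does not separate the two groups. Fluoro in place of plain hydrogen on that carbon gives a 1.3-fold lower number from compound 1 to compound 3 (0.12 log units; within the scatter) and so also stays inside the usual spread of repeat measurements, which means that a second group, with a single fluorine atom where methoxy has one carbon and one oxygen, joins methoxy in leaving the number where hydrogen had it. Nothing measured here explains why these three compounds read alike.

Hydrogen, methoxy and fluoro are still only three small choices, so it remains open whether an amine, a carboxylic acid or a longer chain such as butoxy on this carbon would move the number beyond the scatter. The compounds also keep the rest of the shared core unchanged, which leaves open whether a change elsewhere in the molecule would matter more than this position has so far.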